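A Second Fluorine on the Pendant Phenyl Ring

The compounds below may be only part of what the source reports. "The series", "measured", "known", "first", "only" and "open" are said of these compounds alone.

Three compounds share one core and differ only in the aryl group on a saturated ring carbon. Compound 3 `COc1cc(C2=NN(C(C)=O)C(c3cccc(F)c3)O2)cc(OC)c1OC` carries a 3-fluorophenyl there, and in a functional assay on PC-3 cells (Homo sapiens) for antiproliferative activity, read by MTT assay, tested at 5 uM (a higher number here means a stronger effect of the compound at the concentration tested, a lower number a weaker effect), compound 3 gives 43.5%, the second highest of the three numbers. Compound 1 `COc1ccc(C2OC(c3cc(OC)c(OC)c(OC)c3)=NN2C(C)=O)c(OC)c1` gives 92%, and compound 2 `COc1cc(C2=NN(C(C)=O)C(c3ccccc3C(F)(F)F)O2)cc(OC)c1OC` gives 15.2%. The steps among them are large: a number 48.5 percentage points lower from compound 1 to compound 3 (beyond the scatter), a number 76.8 percentage points lower from compound 1 to compound 2 (beyond the scatter), and a number 28.3 percentage points higher from compound 2 to compound 3 (beyond the scatter). Each of these swaps the whole aryl group, so they show that this position matters strongly but say nothing direct about adding a single fluorine.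

Compound 4 `COc1cc(C2=NN(C(C)=O)C(c3ccc(F)c(F)c3)O2)cc(OC)c1OC` differs from compound 3 by one change: fluoro in place of hydrogen on an aromatic carbon. Among the compounds with values here, no measured step isolates such a small addition, so there is no firm basis for a direction. The expectation is a step of a number 1.5 percentage points higher from compound 3 to compound 4 (within the scatter), within the scatter, with wide uncertainty. Compound 4 is therefore estimated at 45%, between 20% and 72%.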

Compound 4, a percentage reported as inhibition, at one concentration (the size of the read-out at that concentration, not a potency): 46.9%
The estimate for compound 4 lay 1.9 percentage points below the measured number; the measured number falls inside the stated range.
By their numbers in this assay, from the lowest: compound 2; then compounds 3 and 4 (each within the scatter of the next); then compound 1.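

In this assay, the step for fluoro in place of hydrogen on this aromatic carbon, ortho to a fluoro group and para to a large group, is a number 3.4 percentage points higher from compound 3 to compound 4 (within the scatter), so a single fluorine here produces no readable change. The 3,4-difluorophenyl compound also stands apart from the other two much as the 3-fluorophenyl compound does, with a number 31.7 percentage points higher from compound 2 to compound 4 (beyond the scatter) and a number 45.1 percentage points lower from compound 1 to compound 4 (beyond the scatter), so the large differences among these four compounds appear only when the whole aryl group is swapped. No measurement shown explains why these aryl groups differ so strongly.

From the compounds shown here alone, it remains open whether a different group on this same aromatic carbon, such as an amine or a carboxylic acid, would also leave the number unchanged. The compounds also leave open which of the two methoxy groups of the 2,4-dimethoxyphenyl ring matters more for the high number of compound 1, or whether both are needed.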